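The source may report more compounds than this note shows. Statements on the series, on what has been measured and on what is new or still open speak of the compounds shown alone.

In a physicochemical assay for solubility (a lower number here means a less soluble compound, a higher number a more soluble compound), compound 1 `CN1CCN(c2cc(C(F)(F)F)ccc2[C@H]2CCOc3cc(S(=O)(=O)Nc4nccs4)ccc32)CC1` gives 176000 nM, while compound 2 `O=S(=O)(Nc1nccs1)c1ccc2c(c1)OCC[C@@H]2c1ccc(C(F)(F)F)cc1-c1nccs1` gives 15000 nM, the lower of the two numbers. Compound 3 `O=S(=O)(Nc1nccs1)c1ccc2c(c1)OCC[C@@H]2c1ccc(C(F)(F)F)cc1-n1ccnn1` has 1H-1,2,3-triazol-1-yl in place of 1,3-thiazol-2-yl on an aromatic carbon. Within the data shown here, only one measured step bears on this change, and it only loosely: a 12-fold lower number from compound 1 to compound 2 (1.07 log units; beyond the scatter). That step exchanged a different kind of group at the same place, and no swap between five-membered aromatic rings has been measured. A much smaller step, toward a higher number, is therefore expected in this assay. The estimated step is a 1.7-fold higher number from compound 2 to compound 3 (0.22 log units; within the scatter). For compound 3 the expected value is 25000 nM, within an estimated range of 10000 nM to 70000 nM.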

Compound 3, solubility: 171000 nM
Compound 3: middle estimate off by 6.8-fold (0.84 log units), on the low side, and the stated range ends below it.
By their numbers in this assay, from the lowest: compound 2; then compounds 3 and 1 (each within the scatter of the next).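

In this assay the exchange between these two five-membered aromatic rings, on an aromatic carbon ortho to a large group, is no small one: 1H-1,2,3-triazol-1-yl in place of 1,3-thiazol-2-yl gives an 11-fold higher number from compound 2 to compound 3 (1.06 log units; beyond the scatter) and sets the two rings clearly apart. The same triazole against 4-methylpiperazin-1-yl gives a 1.0-fold lower number from compound 1 to compound 3 (0.01 log units; within the scatter), so among these three groups only 1,3-thiazol-2-yl stands apart. No measurement given here accounts for this. Open, going by these compounds, is how a primary amine or a carboxylic acid on this aromatic carbon would read, and whether the gap between the two rings persists with another group in place of trifluoromethyl.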